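Trifluoromethyl for methoxy on the aryl piperazine of compound 3

This account rests on a few compounds, and the source may have more. Where it says the series, first, only, none or still open, it means among the compounds named here.

Compound 1, `CCCc1nc(-c2ccccc2)c(CNCCCN2CCN(c3cccc(C(F)(F)F)c3)CC2)o1`, gives 51.6% in an assay on HEK293 cells for inhibition of Voltage-dependent T-type calcium channel subunit alpha-1G (Homo sapiens), read by fluorescence, tested at 10 uM; a lower number here means less inhibition, a higher number more inhibition at the concentration tested (going by the name of the read-out).
Compound 2, `CCCc1nc(-c2ccccc2)c(CNCCCN2CCN(c3cccc(F)c3)CC2)o1`, gives 68.9% in this assay.
Compound 3, `CCCc1nc(-c2ccccc2)c(CNCCCN2CCN(c3ccc(OC)cc3)CC2)o1`, gives 42.1% in this assay.

Compound 3 holds the lowest of the three numbers. One of its two steps, a number 9.5 percentage points lower from compound 1 to compound 3 (within the scatter), stays within the scatter, while the other, a number 26.8 percentage points lower from compound 2 to compound 3 (beyond the scatter), is a modest step beyond it. Compound 4, `CCCc1nc(-c2ccccc2)c(CNCCCN2CCN(c3ccc(C(F)(F)F)cc3)CC2)o1`, is built from compound 3 by one change: trifluoromethyl in place of methoxy on an aromatic carbon. Going by the values given here, no measured pair shows this exact exchange at the same position. The closest guide is compound 1, which carries the trifluoromethyl on the same ring at another position and sits within the scatter of compound 3, as a number 9.5 percentage points lower from compound 1 to compound 3 (within the scatter) shows; the fluoro analogue, compound 2, lies higher, as a number 17.3 percentage points higher from compound 1 to compound 2 (beyond the scatter) shows. From this, the step of a number 5.9 percentage points higher from compound 3 to compound 4 (within the scatter) is expected to be small, if anything slightly upward toward compound 1, and within the scatter. Compound 4 is therefore estimated at 48% in this assay, with a range from 30% to 66%.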

Compound 4, a percentage reported as inhibition, at one concentration (the size of the read-out at that concentration, not a potency): 51.6%
The estimate for compound 4 lay 3.6 percentage points below the measured number; measured number inside the range.
By their numbers in this assay, from the lowest: compounds 3, 1 and 4 (each within the scatter of the next); then compound 2.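

Read as a direct exchange, trifluoromethyl in place of methoxy on this aromatic carbon gives a number 9.5 percentage points higher from compound 3 to compound 4 (within the scatter) in this assay and so does not separate the two groups at this place. Going by these compounds alone, the comparison of 4-(trifluoromethyl)phenyl with 3-(trifluoromethyl)phenyl, which the earlier compounds could not offer, gives no change at the digits printed from compound 1 to compound 4 (within the scatter) and so shows no effect of where the trifluoromethyl sits that this read-out can resolve, while a number 17.3 percentage points lower from compound 2 to compound 4 (beyond the scatter) leaves compound 2 as the highest of the four, with its steps to each of the other three beyond the scatter. Nothing among the data shown explains these numbers.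

From the compounds shown here alone, whether fluoro at the place para to a large group would keep the number of compound 2 remains open, as fluoro appears here only in the 3-fluorophenyl compound. Also open is how this position would read with a group of another kind, such as a carboxylic acid or an amine, and how any of these compounds would compare as full concentration series rather than at a single concentration.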